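The compounds below may be only part of what the source reports. "The series", "measured", "known", "first", "only" and "open" are said of these compounds alone.

Three compounds of the series have numbers in an ADME assay on HEK293 cells (Homo sapiens) for cytotoxicity, read by CCK-8 assay and cell counting, with a stated time of 2 days; on this read-out higher numbers stand for weaker inhibition and lower numbers for stronger inhibition. Compound 1 `Oc1cccc(-c2cc(-c3ccc(Cl)cc3)nc(-c3cccs3)c2)c1` gives 11800 nM, compound 2 `Oc1ccc(-c2cc(-c3ccsc3)nc(-c3cccc(Cl)c3)c2)cc1` gives 2670 nM, and compound 3 `Oc1cccc(-c2cc(-c3cccc(Cl)c3)nc(-c3cccs3)c2)c1` gives 3150 nM. Among the compounds with values here, compound 3 stands second highest of the three: its number and that of compound 2 lie within the scatter of each other, while the only step beyond the scatter is a 3.7-fold lower number from compound 1 to compound 3 (0.57 log units; beyond the scatter). Compound 4 `Oc1cccc(-c2cc(-c3ccccc3)nc(-c3cccc(Cl)c3)c2)c1` differs from compound 3 by phenyl in place of thiophen-2-yl on an aromatic carbon. Within the data shown here, no measured step changes this group: the one known step, a 3.7-fold lower number from compound 1 to compound 3 (0.57 log units; beyond the scatter), concerns a different group, and compound 2 differs from compound 3 in more than one place. With nothing bearing on the change, no step beyond the scatter is expected in this assay. Compound 4 is therefore estimated at 3000 nM, with a range of 1200 nM to 8000 nM. That estimate means a 1.1-fold lower number from compound 3 to compound 4 (0.02 log units; within the scatter).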

Compound 4, half-maximal inhibitory concentration: 3120 nM
Compound 4: the middle estimate sits 1.0-fold (0.02 log units) below what was measured, within the range that was stated.
By their numbers in this assay, from the lowest: compounds 2, 4 and 3 (each within the scatter of the next); then compound 1.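

At the position next to the ring nitrogen, this assay shows a 1.0-fold lower number from compound 3 to compound 4 (0.00 log units; within the scatter), so phenyl and thiophen-2-yl cannot be told apart here with the 3-chlorophenyl and 3-hydroxyphenyl groups in place. Within the data shown here, this is the first measured change at this position, and exchanging the sulfur-containing five-membered ring for an all-carbon six-membered ring leaves the number within the scatter. Nothing measured accounts for this result.

From the compounds shown here alone, whether an amine or a carboxylic acid at this position would behave in the same way remains open. So does whether phenyl would match thiophen-2-yl alongside 4-chlorophenyl.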